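The source may hold more compounds than are shown below. What is called first, only, known or untested is meant among the compounds shown, and "the series" means these compounds.

Compound 1, `O=C(C1CCC1)N1CC2CC(C1)N2` — in an assay on CHO cells for agonist activity at Neuronal acetylcholine receptor; alpha3/alpha6/beta2/beta3 (Homo sapiens), read by FLIPR and calcium flux (a lower number here means a smaller maximal response, a higher number a larger maximal response), compound 1 gives 80%
Compound 2, `O=C(C1CCCC1)N1CC2CC(C1)N2` — compound 2 gives 62%
Compound 3, `O=C(CC1C=CCC1)N1CC2CC(C1)N2` — compound 3 gives 47%

These three compounds share one core, a bicyclic amine carrying an amide, and differ only in the group attached to the carbonyl carbon. Compound 1 stands highest of the three numbers. Its nearest neighbour is compound 2, whose value lies well below it, a gap that is beyond the usual scatter of this assay; compound 3 lies furthest away, lower still, also beyond the scatter. Among the measured compounds, then, the smallest ring on the carbonyl carbon goes with the largest maximal response, though with only three compounds this is no more than what these numbers show.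

Compound 4, `C[C@@H]1C[C@@H]1C(=O)N1CC2CC(C1)N2`, is not yet measured. It differs from compound 1 in one place: a group of 4 heavy atoms (4 carbon; one three-membered non-aromatic ring of carbon only) in place of a group of 4 heavy atoms (4 carbon; one four-membered non-aromatic ring of carbon only), on a carbonyl carbon. The count of heavy atoms is unchanged; only the ring size and the stereocentres differ.

For the measured compounds named here, no step between two measured compounds mirrors this exchange, so the expectation rests on compound 1 alone. Because compound 1 gives 80%, the step from compound 1 to compound 4 is expected to be small, a number 5 percentage points lower from compound 1 to compound 4 (within the scatter), most likely within the scatter. Compound 4 is therefore estimated at 75%, with a range from 58% to 92%.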

Compound 4, largest response reached (Emax), in percent of the reference or control that the assay uses: 87%
Beside the measured number, compound 4's estimate is 12 percentage points below it; measured number inside the range.
By their numbers in this assay, from the lowest: compound 3; then compound 2; then compounds 1 and 4 (each within the scatter of the next).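

This exchange on the carbonyl carbon, with an amide-type nitrogen in a ring as its other neighbour, replaces cyclobutyl with a group carrying one three-membered carbon ring and 2 defined stereocentres, and in this assay it gives a number 7 percentage points higher from compound 1 to compound 4 (within the scatter). For the compounds shown here, it is the first single exchange that can be read at this position, and it shows that the four-membered ring of compound 1 is not needed for a large maximal response: a different carbon-only group with the same count of heavy atoms, 4 carbon atoms, keeps the response within the usual scatter. Nothing measured here explains why these two groups give such similar responses, so the result describes what happens without giving a reason.

The compounds shown leave open whether a response of this size survives on the carbonyl carbon with groups that are not carbon-only rings, such as an amine, a phenyl ring or a longer chain. They also leave open whether a plain cyclopropyl group, or the opposite arrangement of the two stereocentres in compound 4, would give the same response.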